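The source may report more compounds than this note shows. Statements on the series, on what has been measured and on what is new or still open speak of the compounds shown alone.

Compound 1 `Oc1cccc(-c2cc(-c3ccccc3Cl)cc(-c3ccsc3)n2)c1`, compound 2 `Oc1cccc(-c2cc(-c3ccccc3Cl)cc(-c3ccccc3)n2)c1` and compound 3 `Oc1cccc(-c2cc(-c3ccc(Cl)cc3)cc(-c3ccsc3)n2)c1` are three close relatives built on one shared core. In a functional assay on T47D cells (Homo sapiens) for cytotoxicity, read by CCK-8 assay and cell counting, with stated times of 4 h and 2 days (on this read-out higher numbers stand for weaker inhibition and lower numbers for stronger inhibition), compound 1 gives 680 nM, compound 2 gives 680 nM and compound 3 gives 680 nM. The change phenyl in place of thiophen-3-yl on an aromatic carbon produced the step of no change at the digits printed from compound 1 to compound 2 (within the scatter). The cores of compound 1 and compound 3 differ by 4-chlorophenyl in place of 2-chlorophenyl on an aromatic carbon, and that produced no change at the digits printed from compound 1 to compound 3 (within the scatter). Compound 4 `Oc1cccc(-c2cc(-c3ccc(Cl)cc3)cc(-c3ccccc3)n2)c1` has not yet been measured. It differs from compound 3 by phenyl in place of thiophen-3-yl on an aromatic carbon, the same kind of change as from compound 1 to compound 2, though not the same: there the place was meta to a 2-chlorophenyl group, here it is meta to a 4-chlorophenyl group. The expected step is no change at the digits printed from compound 3 to compound 4 (within the scatter), resting on the earlier step of no change at the digits printed from compound 1 to compound 2 (within the scatter). In this assay compound 4 is therefore estimated at 680 nM, with a likely range from 340 nM to 1400 nM.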

Compound 4, half-maximal inhibitory concentration: 680 nM
Compound 4: middle estimate and measured number agree at the digits printed; measured number inside the range.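

The swap of thiophen-3-yl for phenyl gives no change at the digits printed from compound 3 to compound 4 (within the scatter), and it carries over from one core to the other: the same change on two cores in this assay, no change at the digits printed (within the scatter) from compound 1 to compound 2 and no change at the digits printed (within the scatter) from compound 3 to compound 4, 1.0-fold (0.00 log units) apart, within the scatter of two such steps. The swap of 2-chlorophenyl for 4-chlorophenyl gives no change at the digits printed from compound 2 to compound 4 (within the scatter), and it also carries over: the same change on two cores in this assay, no change at the digits printed (within the scatter) from compound 1 to compound 3 and no change at the digits printed (within the scatter) from compound 2 to compound 4, 1.0-fold (0.00 log units) apart, within the scatter of two such steps. Within the data shown here, neither swap moves the read-out in this assay, so this shows only that two swaps without a visible effect stay without one on these cores, not that a swap with a real effect would carry over in the same way.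

The 3-hydroxyphenyl group is the same in all four compounds. From the compounds shown here alone, what an amine or a carboxylic acid in place of its hydroxyl would do in this assay stays open.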